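A few compounds are considered here, and "the series" means these few. Any claim that something is new, unique, unknown or untested is made for them only; others in the source may bear on it.

Working notes on the series. Three measured compounds share one core and differ only in the group on the carbonyl carbon. Compound 1 `COc1ccc(-c2cc3ccccc3nc2/C=C/C(=O)c2ccc(OC)cc2OC)cc1` gives 3210 nM in a functional assay on MDA-MB-231 cells (Homo sapiens) for antiproliferative activity, read by XTT assay, with a stated time of 72 h; on this read-out higher numbers stand for weaker inhibition and lower numbers for stronger inhibition. Compound 2 `COc1ccc(-c2cc3ccccc3nc2/C=C/C(=O)c2c(OC)cccc2OC)cc1` gives 5630 nM in this assay; the step of a 1.8-fold higher number from compound 1 to compound 2 (0.24 log units; within the scatter). Compound 3 `COc1ccc(-c2cc3ccccc3nc2/C=C/C(=O)c2ccco2)cc1` gives 630 nM in this assay, the lowest of the three numbers; the steps of a 5.1-fold lower number from compound 1 to compound 3 (0.71 log units; beyond the scatter) and an 8.9-fold lower number from compound 2 to compound 3 (0.95 log units; beyond the scatter) both lie beyond the scatter, so compound 3 stands as the strongest inhibitor measured so far.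

Compound 4 `COc1ccc(-c2cc3ccccc3nc2/C=C/C(=O)c2ccsc2)cc1` keeps the core of compound 3 and alters only the group on the carbonyl carbon: thiophen-3-yl in place of furan-2-yl on a carbonyl carbon. Among the measured compounds shown here, no measured step exchanges one five-membered aromatic ring for another at this place. For the measured compounds named here, the two steps that bear on it, a 5.1-fold lower number from compound 1 to compound 3 (0.71 log units; beyond the scatter) and an 8.9-fold lower number from compound 2 to compound 3 (0.95 log units; beyond the scatter), show only that a five-membered ring here gives a lower number than either dimethoxyphenyl, and say nothing about furan-2-yl against thiophen-3-yl. The change keeps the count of heavy atoms and acceptors, so no step beyond the scatter is expected in this assay, with a slight lean toward a higher number because the furan-2-yl of compound 3 set the lowest value at 630 nM.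

Compound 4 is therefore expected to give about 850 nM in this assay, within a range from 350 nM to 2000 nM. This estimate means an expected step of a 1.3-fold higher number from compound 3 to compound 4 (0.13 log units; within the scatter).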

Compound 4, half-maximal inhibitory concentration: 1060 nM
For compound 4 the middle estimate is 1.2-fold (0.10 log units) below the measured one; the range from low to high includes it.
By their numbers in this assay, from the lowest: compounds 3 and 4 (each within the scatter of the next); then compounds 1 and 2 (each within the scatter of the next).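

In this assay, among the compounds shown here, the first exchange of one five-membered aromatic ring for another on the carbonyl carbon gives a 1.7-fold higher number from compound 3 to compound 4 (0.23 log units; within the scatter), so furan-2-yl and thiophen-3-yl cannot be told apart at this position, although the enter and leave groups differ in their hetero atom, oxygen against sulfur. Thiophen-3-yl also keeps the gain over both dimethoxyphenyl groups, with a 5.3-fold lower number from compound 2 to compound 4 (0.73 log units; beyond the scatter) and a 3.0-fold lower number from compound 1 to compound 4 (0.48 log units; beyond the scatter), so among the compounds shown the lower numbers are not confined to furan-2-yl: both five-membered rings give lower numbers than both dimethoxyphenyl groups, and no compound shown goes against this. No measurement at hand accounts for these differences.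

The compounds shown leave open how furan-3-yl and thiophen-2-yl would compare, which would be needed to separate the hetero atom from the point of attachment in this exchange. Also open, from the compounds shown here alone, is whether an aromatic ring is needed on the carbonyl carbon at all, since neither a ring carrying an amine, such as pyrrol-2-yl, nor an open alkyl chain, such as ethyl, stands among them.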